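From compound 3 to compound 4: adding a chloro group

The source may report more compounds than this note shows. Statements on the series, on what has been measured and on what is new or still open speak of the compounds shown alone.

Compound 1 `CC(C)(C)c1ccc(OC/C(=N\NC(N)=S)c2ccc(Br)cc2)cc1` gives 23800 nM 
Compound 2 `COc1ccc(OC/C(=N\NC(N)=S)c2ccc(Br)cc2)cc1` gives 102000 nM 
Compound 3 `NC(=S)N/N=C(\COc1ccc(F)cc1)c1ccc(Br)cc1` gives 52300 nM 

These values come from an ADME assay on L929 cells (Mus musculus) for cytotoxicity, read by resazurin assay, with a stated time of 96 h (on this read-out lower numbers stand for higher toxicity in this test and higher numbers for lower toxicity in this test), and the three compounds differ in one group on an aromatic carbon. Compound 3 stands with the higher pair of numbers: the data give a 2.0-fold lower number from compound 2 to compound 3 (0.29 log units; within the scatter) and also a 2.2-fold higher number from compound 1 to compound 3 (0.34 log units; beyond the scatter) in this small set.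

The change to compound 4 `NC(=S)N/N=C(\COc1ccc(F)c(Cl)c1)c1ccc(Br)cc1` is chloro in place of hydrogen on an aromatic carbon and amounts to chloro in place of hydrogen on an aromatic carbon, ortho to a fluoro group and meta to a large group. For the measured compounds named here, no measured step adds a group alongside the fluoro, so the evidence is indirect. The nearest guides are the swaps on the same ring. Compound 1, with its tert-butyl, gives the lowest number at 23800 nM and the step away from it to the methoxy compound was modest, with a 4.3-fold higher number from compound 1 to compound 2 (0.63 log units; beyond the scatter) on record. The fluoro and methoxy compounds do not separate. Going by the values given here, a small move toward a lower number is therefore expected, no larger than those steps and possibly within the scatter.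

In this assay compound 4 is expected at 36000 nM within an estimated range of 17000 nM to 70000 nM for repeat measurements. That estimate means a 1.5-fold lower number from compound 3 to compound 4 (0.16 log units; within the scatter) as the expected step.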

Compound 4, half-maximal cytotoxic concentration: 48000 nM
Beside the measured number, compound 4's estimate is 1.3-fold (0.12 log units) below it, and the stated range covers the measured number.
By their numbers in this assay, from the lowest: compounds 1, 4, 3 and 2 (each within the scatter of the next, the first and the last beyond it).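

In this assay, the addition of a chloro group ortho to a fluoro group and meta to a large group gives a 1.1-fold lower number from compound 3 to compound 4 (0.04 log units; within the scatter), so compound 4 cannot be told apart from compound 3. The earlier compounds shown here only exchanged one group for another on an aromatic carbon, as in a 2.2-fold higher number from compound 1 to compound 3 (0.34 log units; beyond the scatter), a step that lies beyond the scatter; here the fluoro group remains, a chlorine is added to the ring, and the read-out shows no separable difference. This position therefore accepts one added chlorine without a readable difference in this test, though no measurement shown explains that outcome.

The compounds shown leave open whether this tolerance is particular to chloro or would extend to other groups at the same position, such as an amine, a carboxylic acid or a longer chain. For the compounds shown here, they also leave open whether a chloro group at this place would read the same if the fluoro group were replaced by the methoxy or tert-butyl group of the earlier compounds.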